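Compound 3 to compound 4: a step among limits

The source may hold more compounds than are shown below. What is called first, only, known or untested is meant among the compounds shown, and "the series" means these compounds.

Compound 1 `COc1cc2nc([S+]([O-])CC(=O)Nc3ccccc3[N+](=O)[O-])nc(Nc3c(Cl)cc(/C=C/C#N)cc3Cl)c2cc1OC` gives the limit > 199000 nM
Compound 2 `COc1cc2nc([S+]([O-])CC(=O)Nc3ccccc3F)nc(Nc3c(Cl)cc(/C=C/C#N)cc3Cl)c2cc1OC` gives the limit > 208000 nM
Compound 3 `COc1cc2nc([S+]([O-])CC(=O)Nc3ccccc3C(F)(F)F)nc(Nc3c(Cl)cc(/C=C/C#N)cc3Cl)c2cc1OC` gives the limit > 192000 nM

All three results come from an ADME assay on MT4 cells (Homo sapiens) for cytotoxicity, read by MTT assay, with a stated time of 5 days (a lower number here means that less compound is tolerated, a higher number that more compound is tolerated), and all three are limits, not numbers. Compound 3 stands at the limit > 192000 nM and has no number of its own, so it cannot be ranked against the other two.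

Compound 4 `COc1cc2nc([S+]([O-])CC(=O)Nc3cccc(C#N)c3)nc(Nc3c(Cl)cc(/C=C/C#N)cc3Cl)c2cc1OC` differs from compound 3 in one place, and the change 3-cyanophenyl in place of 2-(trifluoromethyl)phenyl on an amide-type nitrogen leaves the shared core untouched. In words, 3-cyanophenyl sits in place of 2-(trifluoromethyl)phenyl on an amide-type nitrogen.

For the measured compounds named here, the steps that bear on this are a step that the two limits leave unreadable from compound 1 to compound 2 and a step that the two limits leave unreadable from compound 1 to compound 3 and also a step that the two limits leave unreadable from compound 2 to compound 3 in the same assay. None has a readable size, yet nitro, fluoro and trifluoromethyl all ended at a limit. The entering group is new to this set, so a measurable number cannot be ruled out, but another limit is the likeliest result in this assay for the new compound. The step expected here is a step that the limit leaves unreadable from compound 3 to compound 4 with no direction and nothing beyond the scatter. For compound 4 the estimated value is 200000 nM with an expected range from 70000 nM to 220000 nM on this reasoning.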

Compound 4, half-maximal cytotoxic concentration: >= 70300 nM
Compound 4 was reported as a limit (the forecaster's own chance of this, stated with the estimate: 75%); the middle value does not contradict the limit.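

In this assay compound 4 gives only a limit, >= 70300 nM, not a number. For the compounds shown here, compound 1, compound 2 and compound 3 are also limits, so no step involving compound 4 can be read. The compounds shown leave open the actual half-maximal cytotoxic concentration of all four, and whether exchanging the group on the amide-type nitrogen changes it at all.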